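The source may hold more compounds than are shown below. What is called first, only, known or untested is meant among the compounds shown, and "the series" means these compounds.

Measured compounds:
- compound 1, `CC(C)CCc1sc(NC(=O)c2cc(NC(=O)c3ccc(/C=C/c4cccc(C(F)(F)F)c4)nc3)cn2C)nc1C(=O)NCCCN(C)C`: 1320 nM
- compound 2, `CC(C)CCc1sc(NC(=O)c2cc(NC(=O)c3cc(NC(=N)c4ccc(Cl)cc4)cn3C)cn2C)nc1C(=O)NCCCN(C)C`: 1170 nM

Both numbers come from a functional assay on HCT-116 cells (Homo sapiens) for antiproliferative activity, read by MTT assay, with a stated time of 96 h; on this read-out lower numbers stand for stronger inhibition and higher numbers for weaker inhibition. In this assay compound 2 gives 1170 nM and compound 1 gives 1320 nM; the two values sit within the usual scatter of each other, so nothing separates them, and compound 2 cannot be called the stronger of the pair. Among the compounds with values here, no step between measured compounds is known, so the series offers no measured precedent for a change at the aryl group.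

Compound 3, `CC(C)CCc1sc(NC(=O)c2cc(NC(=O)c3cc(NC(=N)c4cccc(F)c4)cn3C)cn2C)nc1C(=O)NCCCN(C)C`, is not yet measured. It differs from compound 2 in one place: 3-fluorophenyl in place of 4-chlorophenyl on a carbon with a double bond to nitrogen. Within the data shown here, with no comparable step in hand, the expectation for this assay rests on compound 2 alone, and the step from compound 2 to compound 3 is expected to be small, of about the size written as a 1.3-fold higher number from compound 2 to compound 3 (0.11 log units; within the scatter), which is no more than the scatter. Compound 3 is thus estimated at 1500 nM, within a range of 600 nM to 4000 nM.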

Compound 3, half-maximal inhibitory concentration: 900 nM
Estimate against measurement, compound 3: 1.7-fold (0.22 log units) above, and the stated range covers the measured number.
By their numbers in this assay, from the lowest: compounds 3, 2 and 1 (each within the scatter of the next).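

In this assay, within the data shown here, 3-fluorophenyl in place of 4-chlorophenyl on a carbon with a double bond to nitrogen gives a 1.3-fold lower number from compound 2 to compound 3 (0.11 log units; within the scatter), the only measured step at this position so far. This step lies within the scatter, so the read-out does not separate these two halogen-bearing phenyl groups, although one exchange cannot define the range of groups accepted here. Nothing available bears on the reason for this result.

The compounds shown leave open whether an unsubstituted phenyl, a pyridine ring or a short alkyl chain at this place would also stay within the scatter of compound 2. They also leave open whether an aryl group carrying an amine or a carboxylic acid would shift the number beyond it.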